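A few compounds are considered here, and "the series" means these few. Any claim that something is new, unique, unknown or untested is made for them only; others in the source may bear on it.

In a functional assay on OVCAR-3 cells (Homo sapiens) for inhibition, read by sulforhodamine B assay, with a stated time of 48 h, tested at 0.1 uM (on this read-out higher numbers stand for a weaker effect at the one concentration tested and lower numbers for a stronger effect), compound 2 `COc1cc(Cl)cc(-c2nn(-c3cccc(NC(=O)Nc4cccc(C(F)(F)F)c4)c3)cc2-c2ccncc2)c1` gives 98% and stands lowest of the two numbers shown, though within the scatter of compound 1 `COc1cc(Cl)cc(-c2nn(-c3cccc(NC(=O)Nc4ccc(Cl)c(C(F)(F)F)c4)c3)cc2-c2ccncc2)c1`, which gives 99%. Among the compounds with values here, the only measured step, a number 1 percentage points lower from compound 1 to compound 2 (within the scatter), concerns a different place. Compound 3 `COc1cc(Cl)cc(-c2nn(-c3cccc(NC(=O)c4cccc(C(F)(F)F)c4)c3)cc2-c2ccncc2)c1` differs from compound 2 by 3-(trifluoromethyl)phenyl in place of (3-(trifluoromethyl)phenyl)amino on a carbonyl carbon. Within the data shown here, no measured step touches the carbonyl carbon, so nothing here speaks for a shift beyond the scatter, and the one step that was measured also stayed within it. Compound 3 is therefore expected to stay close, a number 1 percentage points lower from compound 2 to compound 3 (within the scatter), at an estimated 97% ranging from 88% to 104%.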

Compound 3, a percentage reported as activity, at one concentration (the size of the read-out at that concentration, not a potency): 108%
Beside the measured number, compound 3's estimate is 11 percentage points below it; measured number above the stated range.
By their numbers in this assay, from the lowest: compounds 2, 1 and 3 (each within the scatter of the next).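

In this assay, the carbonyl carbon now has a measured change: 3-(trifluoromethyl)phenyl in place of (3-(trifluoromethyl)phenyl)amino gives a number 10 percentage points higher from compound 2 to compound 3 (within the scatter). The same place, with (4-chloro-3-(trifluoromethyl)phenyl)amino leaving, gives a number 9 percentage points higher from compound 1 to compound 3 (within the scatter), so removing the amino nitrogen and its hydrogen-bond donor does not separate these compounds beyond the scatter. No supporting evidence bears on this result. Still open, on these data alone, is whether a methylene or a longer chain in place of that amino nitrogen would give a read-out beyond the scatter from compound 2.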